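The source may report more compounds than this note shows. Statements on the series, on what has been measured and on what is new or still open speak of the compounds shown alone.

In a functional assay on MCF7 cells (Homo sapiens) for antiproliferative activity, read by MTT assay, with a stated time of 48 h (on this read-out lower numbers stand for stronger inhibition and higher numbers for weaker inhibition), compound 1 `CC(=O)N1N=C(c2ccc3ccccc3c2)OC1c1ccccc1` gives 2.43 ug/mL, compound 2 `CC(=O)N1N=C(c2ccc3ccccc3c2)OC1c1ccc(Br)cc1` gives 5.07 ug/mL and compound 3 `CC(=O)N1N=C(c2ccc3ccccc3c2)OC1c1ccc(C)cc1` gives 2.9 ug/mL, which places compound 3 within the scatter of both others. Compound 4 `CC(=O)N1N=C(c2ccc3ccccc3c2)OC1c1ccsc1` follows from thiophen-3-yl in place of 4-methylphenyl on a saturated ring carbon, with thiophen-3-yl in place of 4-methylphenyl on a saturated ring carbon. Going by the values given here, no measured compound swaps this ring itself, so the closest evidence comes from small changes on it. There, a 1.2-fold higher number from compound 1 to compound 3 (0.08 log units; within the scatter) and a 1.7-fold lower number from compound 2 to compound 3 (0.24 log units; within the scatter) stay within the scatter, and even the largest, a 2.1-fold higher number from compound 1 to compound 2 (0.32 log units; beyond the scatter), is modest. The expected result is a small change with no clear direction, estimated as a 1.0-fold higher number from compound 3 to compound 4 (0.01 log units; within the scatter), and nothing beyond the scatter. For compound 4 the estimated value is 3 ug/mL, with an expected range from 1.3 ug/mL to 7 ug/mL.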

Compound 4, half-maximal inhibitory concentration: 7.98 ug/mL
Beside the measured number, compound 4's estimate is 2.7-fold (0.42 log units) below it; measured number above the stated range.
By their numbers in this assay, from the lowest: compounds 1, 3, 2 and 4 (each within the scatter of the next, the first and the last beyond it).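

Going by these compounds alone, the first ring exchange at this saturated ring carbon shows that the position does not accept every aromatic ring equally in this assay: thiophen-3-yl gives a 2.8-fold higher number from compound 3 to compound 4 (0.44 log units; beyond the scatter) and a 3.3-fold higher number from compound 1 to compound 4 (0.52 log units; beyond the scatter). Against the 4-bromophenyl ring the exchange gives a 1.6-fold higher number from compound 2 to compound 4 (0.20 log units; within the scatter), so compound 4 and compound 2 cannot be separated. Nothing available explains this shift. Open questions are how a pyridine ring or a saturated cyclohexyl ring would behave here, and whether an amine on the phenyl ring would change the number.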